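This account rests on a few compounds, and the source may have more. Where it says the series, first, only, none or still open, it means among the compounds named here.

Of the compounds shown here, three sharing one core have been measured in a functional assay on NCI-H226 cells (Homo sapiens) for inhibition, read by MTT assay, with a stated time of 48 h, tested at 10 uM; a higher number here means more inhibition at the concentration tested (going by the name of the read-out), a lower number less inhibition. Compound 1 `Cc1ccc(Nc2cc(NC(=O)Nc3c(Cl)cccc3Cl)ncn2)cc1C` gives 41.3%, compound 2 `Cc1cc(F)cc(Nc2cc(NC(=O)Nc3c(Cl)cccc3Cl)ncn2)c1` gives 78.1%, and compound 3 `COc1cc(Br)ccc1Nc1cc(NC(=O)Nc2c(Cl)cccc2Cl)ncn1` gives 43%. On these numbers compound 3 stands second highest of the three, though its gap to compound 1 is within the scatter, while the step of a number 35.1 percentage points lower from compound 2 to compound 3 (beyond the scatter) lies beyond it. Compound 4 `O=C(Nc1cc(Nc2ccc(F)c(Cl)c2)ncn1)Nc1c(Cl)cccc1Cl` differs from compound 3 in one place: 3-chloro-4-fluorophenyl in place of 4-bromo-2-methoxyphenyl on a nitrogen on an aromatic ring. For the measured compounds named here, three measured steps concern exchanges at this same place. The step of a number 1.7 percentage points higher from compound 1 to compound 3 (within the scatter) was small, whereas the steps of a number 36.8 percentage points higher from compound 1 to compound 2 (beyond the scatter) and a number 35.1 percentage points lower from compound 2 to compound 3 (beyond the scatter) were large, so exchanging this group can move the read-out a great deal or hardly at all. Going by the values given here, none of the measured compounds carries the entering group, so the direction of the coming step is open, and the estimate sits between the low and high cases seen so far. Compound 4 is estimated at 55%, with a range from 30% to 82%. The expected step of a number 12 percentage points higher from compound 3 to compound 4 (beyond the scatter) is thus a modest rise, uncertain in size.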

Compound 4, a percentage reported as inhibition, at one concentration (the size of the read-out at that concentration, not a potency): 47.3%
Compound 4: the middle estimate sits 7.7 percentage points above what was measured; measured number inside the range.
By their numbers in this assay, from the lowest: compounds 1, 3 and 4 (each within the scatter of the next); then compound 2.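

In this assay the steps of a number 4.3 percentage points higher from compound 3 to compound 4 (within the scatter) and a number 6 percentage points higher from compound 1 to compound 4 (within the scatter) are both small, whereas the step of a number 30.8 percentage points lower from compound 2 to compound 4 (beyond the scatter) is large. Three differently substituted phenyl groups on this nitrogen now give numbers that cannot be told apart, leaving the 3-fluoro-5-methylphenyl group of compound 2 as the only one that stands clear of them. A fluorine on the ring is not enough on its own, since the 3-chloro-4-fluorophenyl group of compound 4 also carries one, and nothing available explains why compound 2 stands apart.

Which feature of the 3-fluoro-5-methylphenyl group goes with the higher number remains open. So does the outcome for a phenyl ring carrying an amine or a carboxylic acid, or for a cyclohexyl group at this place.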